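Chloro Substitution and Cytotoxicity in HL-60 Cells

This account rests on a few compounds, and the source may have more. Where it says the series, first, only, none or still open, it means among the compounds named here.

Of the compounds shown here, three have so far been measured in a functional assay on HL-60 cells (Homo sapiens) for cytotoxicity, read by luminescence and CellTiter-Glo, with a stated time of 3 days; on this read-out higher numbers stand for weaker inhibition and lower numbers for stronger inhibition. Compound 1 `O=C(Nc1cc(C(F)(F)F)cc(C(F)(F)F)c1)c1ccc(-c2ccccc2)cc1O` gives 1140 nM in this assay. Compound 2 `N#Cc1ccc(NC(=O)c2cc(Cl)ccc2O)cc1` gives 700 nM in this assay, and compound 3 `N#Cc1ccc(NC(=O)c2ccccc2O)cc1` gives 4620 nM in this assay. Compound 3 and compound 2 share a core and differ in one place, (chloro in place of hydrogen on an aromatic carbon); the step of a 6.6-fold lower number from compound 3 to compound 2 (0.82 log units; beyond the scatter) shows that this change lowered the number well beyond the usual scatter. Compound 1 belongs to another core, and the difference between the two cores is not broken down here. The values of compound 1 and compound 2 lie within the usual scatter of each other, so nothing can be said of their order.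

Compound 4 `O=C(Nc1cc(C(F)(F)F)cc(C(F)(F)F)c1)c1cc(Cl)c(-c2ccccc2)cc1O` has not yet been measured. It differs from compound 1 by chloro in place of hydrogen on an aromatic carbon. Among the compounds with values here, this is the same kind of change as the one from compound 3 to compound 2, but not the same: in compound 4 the entering chloro also stands ortho to a phenyl group (6 heavy atoms), a feature the earlier change did not have. Because a 6.6-fold lower number from compound 3 to compound 2 (0.82 log units; beyond the scatter) was seen on the other core, compound 4 is expected to give a lower number than compound 1, though the differing surroundings make a smaller step the more cautious expectation. In this assay compound 4 is estimated at 400 nM, between 150 nM and 1200 nM, which would mean an expected step of a 2.9-fold lower number from compound 1 to compound 4 (0.45 log units; beyond the scatter).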

Compound 4, half-maximal inhibitory concentration: 790 nM
Compound 4: middle estimate off by 2.0-fold (0.30 log units), on the low side; the measured number falls inside the stated range.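

In this assay, chloro in place of hydrogen on the core of compound 1 gave a 1.4-fold lower number from compound 1 to compound 4 (0.16 log units; within the scatter), so no effect of the change can be read on this core. Set beside the earlier step, the same change did not carry over at the same size from one core to the other: the same change on two cores in this assay, a 6.6-fold lower number (0.82 log units; beyond the scatter) from compound 3 to compound 2 and a 1.4-fold lower number (0.16 log units; within the scatter) from compound 1 to compound 4, 4.6-fold (0.66 log units) apart, beyond the scatter of two such steps. Within the data shown here, this shows that the clear shift seen on the core of compound 3 cannot simply be assumed for another core, but it does not show why the two steps part, for each core offers only a single pair, and in compound 4 the entering chloro also stands ortho to a phenyl group, so the core and the immediate surroundings cannot be told apart.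

The compounds shown leave open whether a different group at the same place on the core of compound 1, such as a methyl group, a methoxy group or an amine, would move the number beyond the scatter. They also leave open whether the small step belongs to that core as a whole or to the phenyl group, which a matching pair without the phenyl group could settle.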